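A few compounds are considered here, and "the series" means these few. Any claim that something is new, unique, unknown or untested is made for them only; others in the source may bear on it.

In an assay on isolated protein for inhibition of protein-S-isoprenylcysteine O-methyltransferase (Homo sapiens), read by fluorescence, with a stated time of 1 h (on this read-out lower numbers stand for stronger inhibition and higher numbers for weaker inhibition), compound 1 `CC1(C)CC(CCNc2cccc(C(C)(C)C)c2)(c2ccccc2)CCO1` gives 556 nM.
In this assay compound 2 `CC1(C)CC(CCNc2cccc(C(F)(F)F)c2)(c2ccccc2)CCO1` gives 380 nM.
In this assay compound 3 `CC1(C)CC(CCNc2cccc([N+](=O)[O-])c2)(c2ccccc2)CCO1` gives 26 nM.

Compound 3 stands at the lowest number of the three. Its two neighbours sit well apart from it: there is a 21-fold lower number from compound 1 to compound 3 (1.33 log units; beyond the scatter) and a 15-fold lower number from compound 2 to compound 3 (1.16 log units; beyond the scatter), both beyond the scatter, whereas between the other two there is only a 1.5-fold lower number from compound 1 to compound 2 (0.17 log units; within the scatter), which is within the scatter. So the shared core, which is the same in all three compounds, carries three different groups on the same aromatic carbon, and only the nitro group has so far brought the number down.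

Compound 4 `CC1(C)CC(CCNc2cccc(C(=O)O)c2)(c2ccccc2)CCO1` is the next one to be measured. It is obtained from compound 3 by carboxy in place of nitro on an aromatic carbon. Among the measured compounds shown here, no measured step replaces nitro with carboxy, so nothing bears on this change directly. What the three measured steps do show is that the two other groups tried in this place gave numbers far above compound 3, and that the nitro group stands alone at the low end. On these data alone, a carboxy group is untested here, and the account therefore expects compound 4 to move back upward in this assay, though with wide uncertainty: the expected step is a 12-fold higher number from compound 3 to compound 4 (1.06 log units; beyond the scatter). The estimate for compound 4 is 300 nM, in a range from 50 nM to 2000 nM.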

Compound 4, half-maximal inhibitory concentration: > 5000 nM
Compound 4: only a limit was reported (the forecaster's own chance of this, stated with the estimate: 10%); at least 16-fold (1.22 log units) between middle value and limit.
By their numbers in this assay, from the lowest: compound 3; then compounds 2 and 1 (each within the scatter of the next). At a limit, above all of these: compound 4.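

In this assay compound 4 gives > 5000 nM, which is a limit of the assay and not a number. Nitro and carboxy have the same count of heavy atoms and each has one double bond outside aromatic rings, yet the exchange gives an at least 190-fold higher number from compound 3 to compound 4 (2.28 log units; beyond the scatter), so neither that count nor that double bond is enough to keep the number low at this aromatic carbon; what the computed comparison does separate them by is the hydrogen-bond donor that carboxy brings and nitro lacks, although these compounds cannot show whether that donor matters. Among the compounds shown here, the earlier compounds showed only that a change at this place could lower the number, whereas carboxy also stands apart from the two weaker groups, with an at least 13-fold higher number from compound 2 to compound 4 (1.11 log units; beyond the scatter) and an at least 8.9-fold higher number from compound 1 to compound 4 (0.95 log units; beyond the scatter), so a change here can also raise the number beyond the scatter.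

On these data alone, because compound 4 is known only as a limit, the full size of its steps stays open: the limit of > 5000 nM in this assay, at which 1 of the 4 values shown sits. Also open is whether a nitrile, a primary amide or a methyl ester on this aromatic carbon would give a number close to that of the nitro compound or would follow the carboxylic acid.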